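A few compounds are considered here, and "the series" means these few. Any claim that something is new, unique, unknown or untested is made for them only; others in the source may bear on it.

Measured compounds and values:
- compound 1 `CC(C)(C)Cc1c(-c2ccc(F)cc2F)sc(N)c1C(=O)c1ccc(Cl)cc1`: 1%
- compound 2 `Cc1cccc(-c2sc(N)c(C(=O)c3ccc(Cl)cc3)c2CC(C)(C)C)c1`: 1%

In an assay on CHO cells for displacement of a labelled ligand from adenosine receptor A3 (Homo sapiens), read by scintillation counting, tested at 10 uM (on this read-out higher numbers stand for more inhibition at the one concentration tested (going by the name of the read-out) and lower numbers for less inhibition), compound 1 gives 1%. In this assay compound 2 gives 1%. Going by the values given here, the single measured step, no change at the digits printed from compound 1 to compound 2 (within the scatter), exchanged one aryl ring for another on an aromatic carbon of the shared core and moved the read-out not at all. Compound 2 therefore stands level with compound 1 at the digits shown; neither shows appreciable inhibition at the concentration tested.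

Compound 3 `COc1ccc(-c2sc(N)c(C(=O)c3ccc(Cl)cc3)c2CC(C)(C)C)cc1` is the next member of the series. It differs from compound 2 in one place: 4-methoxyphenyl in place of 3-methylphenyl on an aromatic carbon

The step from compound 1 to compound 2 bears directly on this change, as it is the same kind of exchange of an aryl ring at the same aromatic carbon, and it was flat: no change at the digits printed from compound 1 to compound 2 (within the scatter). Among the compounds with values here, there is no measured step in which a change at this position shifted the read-out, so nothing in the data points to a change in either direction. The expected step is a number 1 percentage points higher from compound 2 to compound 3 (within the scatter), that is, none beyond the scatter. Compound 3 is accordingly estimated at 2%, with a range from -8% to 12%.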

Compound 3, a percentage reported as inhibition, at one concentration (the size of the read-out at that concentration, not a potency): 2%
The estimate for compound 3 equals the measured number at the digits printed; measured number inside the range.
By their numbers in this assay, from the lowest: compounds 1, 2 and 3 (each within the scatter of the next).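

In this assay, 4-methoxyphenyl in place of 3-methylphenyl on the aromatic carbon next to the ring sulfur gives a number 1 percentage points higher from compound 2 to compound 3 (within the scatter), and 4-methoxyphenyl in place of 2,4-difluorophenyl gives a number 1 percentage points higher from compound 1 to compound 3 (within the scatter). Going by these compounds alone, the entering group is the first here to carry an oxygen, and the one hydrogen-bond acceptor it holds, against none in 3-methylphenyl, brings no step beyond the scatter, so the flat picture at this position now extends to a third aryl group. No supporting measurement bears on these readings.

The compounds shown leave open whether a carboxylic acid or an aminomethyl group on this aryl ring, or a cyclohexyl group in place of the ring, would give a reading beyond the scatter of these three. They also leave open what the neopentyl group, the (4-chlorophenyl)carbonyl group and the amino group contribute, as all three compounds share each of them.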